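Cyclobutyl to ethoxy on the carbonyl of compound 3

The compounds below may be only part of what the source reports. "The series", "measured", "known", "first", "only" and "open" are said of these compounds alone.

The series shares a core carrying two amide-type nitrogens, each with its own acyl group. Compound 1 `Cc1ccc(C(=O)Nc2ccc3nc(NC(=O)C4CCCCC4)sc3c2)cc1` gives 5.1 ug/mL in a functional assay on WI-38 VA13 cells (Homo sapiens) for cytotoxicity; a lower number here means that less compound is needed, a higher number that more compound is needed for the effect; compound 2 `Cc1coc(C)c1C(=O)Nc1ccc2nc(NC(=O)C3CCCCC3)sc2c1` gives 2.7 ug/mL; compound 3 `O=C(Nc1ccc2nc(NC(=O)C3CCC3)sc2c1)c1c(Cl)cccc1Cl` gives 0.013 ug/mL. Among the compounds with values here, the only one-place step measured so far, a 1.9-fold lower number from compound 1 to compound 2 (0.28 log units; within the scatter), changes the aryl on the other carbonyl and stays within the scatter. Compound 3 stands lowest of the three numbers; its gap to compound 2 is beyond the scatter, and its gap to compound 1 is larger still, but compound 3 differs from each of them in two places, so neither gap can be assigned to one change.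

Compound 4 `CCOC(=O)Nc1nc2ccc(NC(=O)c3c(Cl)cccc3Cl)cc2s1` differs from compound 3 by ethoxy in place of cyclobutyl on a carbonyl carbon. Within the data shown here, no measured step touches this position, and the one step available concerns a different carbonyl and was within the scatter, so nothing in the data indicates a direction. The cyclobutyl ring is lost and an oxygen enters with one hydrogen-bond acceptor; in the absence of a comparable step, a modest rise in the number, within a wide range, is the expectation for compound 4: a 3.8-fold higher number from compound 3 to compound 4 (0.59 log units; beyond the scatter), giving an estimated 0.05 ug/mL with a range from 0.005 ug/mL to 0.5 ug/mL.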

Compound 4, half-maximal effective concentration: 0.0026 ug/mL
The estimate for compound 4 lay 19-fold (1.28 log units) above the measured number, outside the stated range (below it).
By their numbers in this assay, from the lowest: compound 4; then compound 3; then compounds 2 and 1 (each within the scatter of the next).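

Within the data shown here, on the carbonyl carbon whose other neighbour is the amide-type nitrogen, ethoxy in place of cyclobutyl gives a 5.0-fold lower number from compound 3 to compound 4 (0.70 log units; beyond the scatter) in this assay as the only step read at this position, and it is the only one-place step so far that lies beyond the scatter. The position is therefore not indifferent to its substituent, whereas the earlier step on the other carbonyl showed no change beyond the scatter. In this pair the cyclobutyl ring is not needed for a low number, as the open ethoxy group, which brings in one hydrogen-bond acceptor, goes lower still, and no accompanying measurement bears on why the number falls.

This single pair does not separate the entry of the oxygen from the loss of the ring: a propyl chain on the same carbonyl, or a cyclobutyloxy group, would pull the two apart. Also open, going by these compounds, is how a dimethylamino group or a longer alkoxy chain such as butoxy behaves at this carbonyl, and whether ethoxy gives a step of similar size with 4-methylphenyl on the other carbonyl.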